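Swapping methyl for fluoro on a sulfonamide tail

The compounds below may be only part of what the source reports. "The series", "measured", "known", "first", "only" and "open" are said of these compounds alone.

Measured compounds:
compound 1 `O=C(CC1c2ccccc2N=C(N2CCCCC2)N1c1ccccc1)NCc1ccccc1` gives 900 nM in a functional assay on HEK293 cells for inhibition of Voltage-dependent T-type calcium channel subunit alpha-1G (Homo sapiens); on this read-out higher numbers stand for weaker inhibition and lower numbers for stronger inhibition
compound 2 `Cc1ccc(S(=O)(=O)Nc2ccc(CNC(=O)CC3c4ccccc4N=C(N4CCCCC4)N3c3ccccc3)cc2)cc1` gives 250 nM in this assay

Among the measured compounds shown here, compound 2 stands with the lowest of the two numbers so far; its nearest neighbour is compound 1, and the one step between them, a 3.6-fold lower number from compound 1 to compound 2 (0.56 log units; beyond the scatter), came from placing a ((4-methylphenyl)sulfonyl)amino group on an aromatic carbon where compound 1 carries hydrogen.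

Compound 3 `O=C(CC1c2ccccc2N=C(N2CCCCC2)N1c1ccccc1)NCc1ccc(NS(=O)(=O)c2ccc(F)cc2)cc1` keeps that sulfonamide and changes only its outer ring: fluoro in place of methyl on an aromatic carbon, on an aromatic carbon of a six-membered aromatic ring of carbon only, para to a large group. For the measured compounds named here, no measured step touches this position, so the only guide is that compound 2 and compound 1 differ in a much larger way than compound 2 and compound 3 do. A swap of one heavy atom for another at the far end of the tail is expected to move this assay little, if at all, beyond the scatter.

Compound 3 is therefore estimated at 250 nM, within 100 nM to 600 nM, a step of no change at the digits printed from compound 2 to compound 3 (within the scatter) that is expected to stay within the usual scatter.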

Compound 3, half-maximal inhibitory concentration: 200 nM
Beside the measured number, compound 3's estimate is 1.3-fold (0.10 log units) above it; the range from low to high includes it.
By their numbers in this assay, from the lowest: compounds 3 and 2 (each within the scatter of the next); then compound 1.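

In this assay, fluoro in place of methyl on the outer ring gives a 1.3-fold lower number from compound 2 to compound 3 (0.10 log units; within the scatter), so at this position, para to a large group, these two single-atom groups cannot be told apart. The sulfonamide tail carrying the fluoro group also gives a 4.5-fold lower number from compound 1 to compound 3 (0.65 log units; beyond the scatter), which shows that the gain over compound 1, first seen with the methyl version, does not depend on that methyl being present. Nothing available here explains why the two groups read alike in this assay.

Going by these compounds, both groups tested at this position contain only one heavy atom, so it remains open whether a larger or very different group, such as a carboxylic acid, an amine or a longer chain, would be tolerated as well, and what plain hydrogen at the same place would give. On these data alone, it is also open whether the outer ring itself is needed for the gain, which could be tested by replacing the 4-fluorophenyl on the sulfonyl group with a simple methyl.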